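Switching the ether link for a direct cyanopyridyl ring

The source may hold more compounds than are shown below. What is called first, only, known or untested is meant among the compounds shown, and "the series" means these compounds.

Among the compounds with values here, compound 3 `CCOc1cc(Oc2cccnc2)cnc1Nc1cccc(C)n1` gives 18 nM in an assay on Ltk cells with metabotropic glutamate receptor 5 (Homo sapiens) as the target, read by fluorescence and calcium flux (on this read-out lower numbers stand for stronger inhibition and higher numbers for weaker inhibition), the lowest of the three numbers measured so far. Compound 1 `CCOc1cc(-c2cccc(F)c2)cnc1Nc1cccc(C)n1` gives 126 nM in this assay, and compound 2 `CCOc1cc(-c2ccsn2)cnc1Nc1cccc(C)n1` gives 243 nM. Both measured steps lead to compound 3 and both lower the number: a 7.0-fold lower number from compound 1 to compound 3 (0.85 log units; beyond the scatter) and a 14-fold lower number from compound 2 to compound 3 (1.13 log units; beyond the scatter). The step between the two others is small, a 1.9-fold higher number from compound 1 to compound 2 (0.29 log units; within the scatter).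

Compound 4 `CCOc1cc(-c2cccnc2C#N)cnc1Nc1cccc(C)n1` differs from compound 3 in one place: 2-cyanopyridin-3-yl in place of (pyridin-3-yl)oxy on an aromatic carbon. The change removes the ether link that compound 3 alone carries and puts a ring straight onto the shared core, as compound 1 and compound 2 have it. The step from compound 1 to compound 3 and the step from compound 2 to compound 3 bear on this, and they point the other way: the compounds with a directly attached ring give higher numbers than compound 3. The expectation is therefore that compound 4 gives a higher number than compound 3, roughly a 4.4-fold higher number from compound 3 to compound 4 (0.65 log units; beyond the scatter), in the region of compound 1. The estimate for compound 4 in this assay is 80 nM, with a range from 25 nM to 250 nM.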

Compound 4, half-maximal inhibitory concentration: 80 nM
Beside the measured number, compound 4's estimate shows no gap at the digits printed; the range from low to high includes it.
By their numbers in this assay, from the lowest: compound 3; then compounds 4, 1 and 2 (each within the scatter of the next, the first and the last beyond it).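

At this position, on the carbon two atoms from the ring nitrogen of the shared core, a third directly attached ring now joins the comparison: in this assay 2-cyanopyridin-3-yl in place of (pyridin-3-yl)oxy gives a 4.4-fold higher number from compound 3 to compound 4 (0.65 log units; beyond the scatter) and so does not match the ether-linked ring, even though it carries the same kind of ring with a nitrile added. The directly attached rings do not all behave alike: there is a 3.0-fold lower number from compound 2 to compound 4 (0.48 log units; beyond the scatter) for 2-cyanopyridin-3-yl in place of 1,2-thiazol-3-yl, whereas a 1.6-fold lower number from compound 1 to compound 4 (0.20 log units; within the scatter) for the change from 3-fluorophenyl leaves those two compounds indistinguishable in this measurement. Nothing among the data shown explains why any of these changes has the size it has.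

The change from compound 3 to compound 4 removes the ether oxygen and adds the nitrile in a single step, so a plain pyridin-3-yl ring attached directly is the group that would separate the two contributions. On these data alone, it also remains open whether the oxygen link itself is what counts, a question that a (pyridin-3-yl)amino or a (pyridin-3-yl)methyl group at this position could address.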